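The compounds below may be only part of what the source reports. "The series", "measured", "known", "first", "only" and "open" are said of these compounds alone.

Compound 1 `O=C(Nc1cccc(-c2cccc(NC(=O)C(Cl)Cl)c2)c1)C(Cl)Cl` is one of three dichloroacetamides examined in a functional assay on NCI-H460 cells (Homo sapiens) for cytotoxicity, read by MTT assay, with a stated time of 68 h; a lower number here means a stronger inhibitor, a higher number a weaker inhibitor. In this assay compound 1 reaches only a limit of the assay, > 50000 nM. Compound 2 `CSc1ccccc1-c1cc(NC(=O)C(Cl)Cl)cc(-c2ccccc2SC)c1` likewise returns only a limit, > 30000 nM. Compound 3 `O=C(Nc1cccc(-c2ccc(C(F)(F)F)cc2)c1)C(Cl)Cl` gives a numerical value, 33600 nM. Compound 1 therefore stands at a limit rather than a number, as does one further value of the set, so its place against the others cannot be fixed. Compound 4 `O=C(Nc1cccc(-c2ccccc2)c1)C(Cl)Cl` differs from compound 1 by hydrogen in place of ((dichloromethyl)carbonyl)amino on an aromatic carbon. Among the compounds with values here, with no measured step of this kind available, compound 4 is expected to stay weak, with an expected step of about a number no higher from compound 1 to compound 4 (the limit leaves the size open), that is, nothing clearly beyond the scatter. Compound 4 is estimated at 50000 nM, in a range from 20000 nM to 120000 nM.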

Compound 4, half-maximal inhibitory concentration: 20200 nM
Compound 4: the middle estimate sits 2.5-fold (0.39 log units) above what was measured, within the range that was stated.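

Hydrogen in place of ((dichloromethyl)carbonyl)amino on an aromatic carbon gives an at least 2.4-fold lower number from compound 1 to compound 4 (0.39 log units; beyond the scatter) in this assay, so the compound keeps measurable activity without this group. Going by these compounds, the exact size of the step stays open because compound 1 stands at a limit: the limit of > 50000 nM in this assay, at which 1 of the 4 values shown sits. Hydrogen in place of trifluoromethyl gives a 1.7-fold lower number from compound 3 to compound 4 (0.22 log units; within the scatter), so this assay does not separate compound 3 from compound 4. The compounds shown leave open whether an amine or a carboxylic acid on this carbon would shift the value beyond the scatter.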